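The source may report more compounds than this note shows. Statements on the series, on what has been measured and on what is new or still open speak of the compounds shown alone.

Measured in a functional assay on HL-60 cells (Homo sapiens) for inhibition, read by CCK-8 assay, with a stated time of 48 h, tested at 20 uM; on this read-out higher numbers stand for more inhibition of growth at the one concentration tested and lower numbers for less inhibition of growth:

- compound 1 `COc1ccc(Cc2nnc(NC(=O)/C(C#N)=C/c3ccccc3OS(=O)(=O)c3ccc(F)cc3)s2)cc1`: 25%
- compound 2 `COc1ccc(S(=O)(=O)Oc2ccccc2/C=C(\C#N)C(=O)Nc2nnc(Cc3cccc(F)c3)s2)cc1`: 100%
- compound 3 `N#C/C(=C\c1ccccc1OS(=O)(=O)c1ccc([N+](=O)[O-])cc1)C(=O)Nc1nnc(Cc2cccc(F)c2)s1`: 18%

Compound 3 at 18% and compound 1 at 25% lie within the usual scatter of each other, while the number for compound 2 at 100% is far higher than either.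

The next compound to consider is compound 4 `N#C/C(=C\c1ccccc1OS(=O)(=O)c1ccc(F)cc1)C(=O)Nc1nnc(Cc2cccc(F)c2)s1`. It differs from compound 3 in one place, where 4-nitrophenyl becomes 4-fluorophenyl, para to a large group: fluoro in place of nitro on an aromatic carbon.

For the measured compounds named here, only one measured step touches this same place: a number 82 percentage points lower from compound 2 to compound 3 (beyond the scatter). That large step, beyond the scatter, shows that a swap here can move the number a long way, but it does not show where fluoro will fall. Compound 1 carries the same (4-fluorophenyl)sulfonyl group and gives 25%, yet it also differs from compound 4 elsewhere in the structure, so it is only a loose guide.

A moderate rise in this assay is therefore expected, with much uncertainty: the estimate is a number 22 percentage points higher from compound 3 to compound 4 (beyond the scatter). For compound 4 the estimated value is 40%, with an expected range from 12% to 85%.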

Compound 4, percent growth inhibition at one concentration: 22%
Beside the measured number, compound 4's estimate is 18 percentage points above it, within the range that was stated.
By their numbers in this assay, from the lowest: compounds 3, 4 and 1 (each within the scatter of the next); then compound 2.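

In this assay, the step from nitro to fluoro at this position is a number 4 percentage points higher from compound 3 to compound 4 (within the scatter) and so does not separate the two groups, whereas the step from methoxy to fluoro is a number 78 percentage points lower from compound 2 to compound 4 (beyond the scatter) and is large. Of the three groups seen at this position, methoxy therefore stands apart, and the loss seen with nitro is not unique to nitro, since fluoro gives a low number as well. With fluoro at this position, the change from 4-methoxyphenyl to 3-fluorophenyl on the saturated chain carbon gives a number 3 percentage points lower from compound 1 to compound 4 (within the scatter), so that other place makes no visible difference in this pair.

No evidence is available on why methoxy behaves differently from nitro and fluoro at this position. Still open, on these data alone, is whether the high number depends on methoxy itself or would also appear with a group such as ethoxy, hydroxy, methyl or an amine, and whether compound 2, at 100% in a test at one concentration, would still stand out at lower concentrations.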